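Oxime series: removing the chloro substituent of compound 1

A few compounds are considered here, and "the series" means these few. Any claim that something is new, unique, unknown or untested is made for them only; others in the source may bear on it.

Measured compounds:
- compound 1 `COc1ccc(C(/C=C/c2ccc(Cl)cc2)=N/O)cc1`: 11500 nM
- compound 2 `COc1ccc(/C=C/C(=N\O)c2ccc(OC)cc2)cc1`: 12300 nM

Within the data shown here, in a functional assay (Mus musculus, strain Balb/c) for inhibition, read by ELISA, with a stated time of 72 h (on this read-out higher numbers stand for weaker inhibition and lower numbers for stronger inhibition), compound 1 gives 11500 nM, the lowest of the two numbers so far; in the same assay compound 2 gives 12300 nM, and the two values lie within the scatter of each other, so no order can be read from them. Among the measured compounds shown here, the only step between measured compounds, a 1.1-fold higher number from compound 1 to compound 2 (0.03 log units; within the scatter), exchanges one substituent on the aromatic carbon for another and leaves the number essentially where it was.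

Compound 3 `COc1ccc(C(/C=C/c2ccccc2)=N/O)cc1` is not yet measured in this assay. It differs from compound 1 as follows: hydrogen in place of chloro on an aromatic carbon. The step from compound 1 to compound 2 is the one that bears on this change, since it also alters the group on that aromatic carbon, and it was within the scatter. On that basis a step of no more than the scatter is expected, with no direction favoured: the expected step is a 1.0-fold higher number from compound 1 to compound 3 (0.02 log units; within the scatter). For compound 3 the estimate in this assay is 12000 nM, with a range of 5500 nM to 26000 nM.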

Compound 3, half-maximal inhibitory concentration: 11800 nM
Beside the measured number, compound 3's estimate is 1.0-fold (0.01 log units) above it; the measured number falls inside the stated range.
By their numbers in this assay, from the lowest: compounds 1, 3 and 2 (each within the scatter of the next).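

In this assay hydrogen in place of chloro gives a 1.0-fold higher number from compound 1 to compound 3 (0.01 log units; within the scatter) and hydrogen in place of methoxy gives a 1.0-fold lower number from compound 2 to compound 3 (0.02 log units; within the scatter). Until now the series offered only an exchange of one substituent for another on this aromatic carbon, para to a large group; the hydrogen compound adds the case with no substituent there at all, and the step to it is as small as the exchange was. Across chloro, methoxy and hydrogen the numbers therefore stay within the scatter of one another, so for these three compounds the presence of a substituent at this position makes no readable difference, and no order among them can be given. Nothing measured here offers an explanation for this flat result.

Whether an amine, a carboxylic acid or a longer chain on this aromatic carbon would shift the number beyond the scatter remains open, since the three groups shown cover only a narrow set of substituents. Also open, as far as these compounds go, is what happens when the change is made elsewhere on the shared core, for example at the oxime hydroxyl or at the methoxy on the other ring.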